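The compounds below may be only part of what the source reports. "The series", "measured", "known", "first", "only" and "open" are said of these compounds alone.

Measured compounds:
compound 1 `Cc1c(OCCCCOc2ccccc2C(=O)O)ccc(C(=O)CC2CCCC2)c1O` — 98.8%
compound 2 `CCCC(=O)c1ccc(OCCCCOc2ccc(F)c(C(=O)O)c2)c(C)c1O` — 87.5%
compound 3 `Cc1cc(C(=O)O)ccc1OCCCCOc1ccc(C(=O)CC2CCCC2)c(O)c1C` — 84.6%

In an assay on HEK293 cells for positive allosteric modulation of metabotropic glutamate receptor 2 (Rattus norvegicus), read by thallium flux, with a stated time of 2.5 min (a higher number here means a larger maximal response, a lower number a smaller maximal response), compound 3 stands lowest of the three numbers; compound 2 is close, within the scatter, while compound 1 sits clearly higher, the step of a number 14.2 percentage points lower from compound 1 to compound 3 (beyond the scatter) being the only one on record. Compound 4 `Cc1c(OCCCCOc2ccc(F)c(C(=O)O)c2)ccc(C(=O)CC2CCCC2)c1O` is reached from compound 3 by the change (3-carboxy-4-fluorophenyl in place of 4-carboxy-2-methylphenyl on an oxygen on a saturated carbon). For the measured compounds named here, no measured step covers this exact change. Compound 2, which carries the same 3-carboxy-4-fluorophenyl tail on a different ketone, gives a value within the scatter of compound 3, so no step beyond the scatter is expected in this assay. Compound 4 is therefore estimated at 88% (range 75% to 100%), an expected step of a number 3.4 percentage points higher from compound 3 to compound 4 (within the scatter).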

Compound 4, largest response reached (reported as percent of maximum), in percent of the reference or control that the assay uses: 81%
For compound 4 the middle estimate is 7 percentage points above the measured one; the measured number falls inside the stated range.
By their numbers in this assay, from the lowest: compounds 4, 3 and 2 (each within the scatter of the next); then compound 1.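

In this assay, 3-carboxy-4-fluorophenyl in place of 4-carboxy-2-methylphenyl on the oxygen gives a number 3.6 percentage points lower from compound 3 to compound 4 (within the scatter) and so does not separate these two tails. Cyclopentyl in place of ethyl gives a number 6.5 percentage points lower from compound 2 to compound 4 (within the scatter) and adds a second change that stays unresolved at this read-out. Against 2-carboxyphenyl, the same fluorinated tail gives a number 17.8 percentage points lower from compound 1 to compound 4 (beyond the scatter) and, like the step to compound 3, sets the tail of compound 1 apart.

Nothing at hand explains that gap. Open, on these data alone, is how an amide or tetrazole in place of the carboxylic acid, or a shorter chain between the two oxygens, would read.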